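Replacing the formyl group of compound 2

This account rests on a few compounds, and the source may have more. Where it says the series, first, only, none or still open, it means among the compounds named here.

In an ADME assay on J774 cells (Mus musculus) for cytotoxicity, read by MTT assay, with a stated time of 48 h (a higher number here means a weaker inhibitor, a lower number a stronger inhibitor), compound 1 `[O-][n+]1onc2ccc(/C=N/NC(=S)Nc3ccccc3)cc21` gives < 50000 nM, which is a limit and not a number. Compound 2 `O=Cc1ccc(OCc2ccc3no[n+]([O-])c3c2)cc1` gives 60000 nM, the lower of the two actual numbers. In the same assay, compound 3 `N=C(N/N=C/c1ccc(O)cc1)SCc1ccc2no[n+]([O-])c2c1` gives 142000 nM, a gap beyond the scatter. Compound 4 `N=C(N)N/N=C/c1ccc(OCc2ccc3no[n+]([O-])c3c2)cc1` departs from compound 2 at one place, where the formyl group on an aromatic carbon, para to a large group, is replaced: a group of 6 heavy atoms (2 carbon, 4 nitrogen; no ring) in place of a group of 2 heavy atoms (1 carbon, 1 oxygen; no ring), on an aromatic carbon. Going by the values given here, no measured pair shows this kind of change, so only a small shift towards a lower number is expected in this assay, within the scatter. The estimated step is a 1.2-fold lower number from compound 2 to compound 4 (0.08 log units; within the scatter). For compound 4, the expected value is 50000 nM, with an estimated range of 15000 nM to 150000 nM.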

Compound 4, half-maximal inhibitory concentration: < 50000 nM
Compound 4: a limit, no number (the forecaster's own chance of this, stated with the estimate: 25%); the middle value sits exactly at the limit.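

Going by these compounds alone, this is the first pair differing in one place, and in this assay the change gives an at least 1.2-fold lower number from compound 2 to compound 4 (0.07 log units; that floor lies within the scatter), so the larger group at this position brings no move to a higher number. Compound 4 carries a limit, < 50000 nM, and not a number. The full size of the step cannot be read, as the reading stops at a limit: the limit of < 50000 nM in this assay, at which 2 of the 4 values shown sit.

Going by these compounds, how far the true value of compound 4 lies past that limit stays open. So does whether an amine or a carboxylic acid on this aromatic carbon would give a step beyond the scatter.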